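The compounds below may be only part of what the source reports. "The series", "measured", "known", "first", "only" and "open" are said of these compounds alone.

Measured compounds:
compound 1, `CCSC(=S)SCC(=O)c1ccc(NC(=O)c2cccnc2)cc1`, 421 nM
compound 2, `CCOC(=S)SCC(=O)c1ccc(OC)cc1`, 448 nM
compound 3, `CCSC(=S)SCC(=O)c1ccc(C(=O)NCCOc2ccccc2)cc1`, 483 nM

All three were tested in an assay on HEK293 cells for inhibition of protein deacetylase HDAC6 (Homo sapiens); a higher number here means a weaker inhibitor, a lower number a stronger inhibitor. In this assay compound 1 gives 421 nM, the lowest of the three numbers, yet it lies within the usual scatter of compound 2, which gives 448 nM, and of compound 3, which gives 483 nM. None of the three can therefore be called stronger or weaker than another; they share a core and differ in what hangs from it, and those differences leave the numbers indistinguishable.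

Compound 4, `CCSC(=S)SCC(=O)c1ccc(NS(C)(=O)=O)cc1`, has not yet been measured. It differs from compound 1 in one place: methylsulfonyl in place of (pyridin-3-yl)carbonyl on a nitrogen on an aromatic ring. The measured compounds carry rather different groups on the shared core, yet compound 2 at 448 nM and compound 3 at 483 nM both fall within scatter of compound 1; on that basis the change is expected to move the number little, in no clear direction. Compound 4 is expected to differ by a 1.1-fold higher number from compound 1 to compound 4 (0.03 log units; within the scatter), which is not beyond the scatter. Compound 4 is therefore estimated at 450 nM, with a range from 200 nM to 1000 nM.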

Compound 4, half-maximal inhibitory concentration: 1090 nM
Compound 4: middle estimate off by 2.4-fold (0.38 log units), on the low side, and the stated range ends below it.
By their numbers in this assay, from the lowest: compounds 1, 2 and 3 (each within the scatter of the next); then compound 4.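

In this assay methylsulfonyl in place of (pyridin-3-yl)carbonyl on a nitrogen on an aromatic ring gives a 2.6-fold higher number from compound 1 to compound 4 (0.41 log units; beyond the scatter) and so a weaker inhibitor, a modest step but one beyond the scatter. The earlier compounds shown here differ from one another in more than one place and so could not show this: here, with the rest of the molecule held constant, the group on this nitrogen is seen to affect the number. The change swaps a larger group with a six-membered aromatic ring for a smaller one with no ring, and nothing measured here says which part of that swap accounts for the step.

On these data alone, what remains open is whether the ring or the link to the nitrogen matters more: acetyl would keep the carbonyl without the ring, while phenylsulfonyl would keep a sulfonyl and restore a ring. The compounds shown also leave open how the free amine, with nothing added on that nitrogen, would compare.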